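The source may hold more compounds than are shown below. What is called first, only, known or untested is meant among the compounds shown, and "the series" means these compounds.

Among the measured compounds shown here, compound 1 `O=C(Nc1cccc(-n2cc(-c3ccncc3)c(-c3ccc(Cl)c(O)c3)n2)c1)Nc1cccc(C(F)(F)F)c1` stands at the higher of the two numbers so far: in a functional assay on CAKI-1 cells (Homo sapiens) for inhibition, read by sulforhodamine B assay, with a stated time of 48 h (a lower number here means a stronger inhibitor of growth, a higher number a weaker inhibitor of growth), compound 1 gives 1750 nM. For the measured compounds named here, its only measured neighbour, compound 2 `COc1cc(-c2nn(-c3cccc(NC(=O)Nc4cccc(C(F)(F)F)c4)c3)cc2-c2ccncc2)ccc1Cl`, gives 1030 nM in this assay, and the step of a 1.7-fold lower number from compound 1 to compound 2 (0.23 log units; within the scatter), methyl in place of hydrogen on an oxygen on an aromatic ring, is the single measured change.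

Compound 3 `O=C(Nc1cccc(-n2cc(-c3ccncc3)c(-c3ccc(Cl)c(O)c3)n2)c1)Nc1ccc(Cl)c(C(F)(F)F)c1` differs from compound 1 by chloro in place of hydrogen on an aromatic carbon, ortho to a trifluoromethyl group and para to a large group. Going by the values given here, no measured step touches this ring; the step from compound 1 to compound 2 sits elsewhere and is within the scatter, so it gives no direction here. The expectation is therefore a step of a 1.2-fold lower number from compound 1 to compound 3 (0.07 log units; within the scatter) that stays within the scatter. Compound 3 is estimated at 1500 nM, within 600 nM to 4000 nM.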

Compound 3, concentration for 50% growth inhibition: 795 nM
Beside the measured number, compound 3's estimate is 1.9-fold (0.28 log units) above it; the measured number falls inside the stated range.
By their numbers in this assay, from the lowest: compounds 3, 2 and 1 (each within the scatter of the next, the first and the last beyond it).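

In this assay, the change from 3-(trifluoromethyl)phenyl to 4-chloro-3-(trifluoromethyl)phenyl gives a 2.2-fold lower number from compound 1 to compound 3 (0.34 log units; beyond the scatter), a modest step and the first in the series to lie beyond the scatter. This places a measurable effect on the ring carrying the trifluoromethyl group, a ring the earlier step did not touch, though it rests on this single pair. No available evidence bears on the reason for this step.

The compounds shown leave open whether this step is specific to chloro or would also appear with fluoro, methyl, methoxy or an amine on the same carbon. They also leave open whether chloro on this ring would give a similar step when combined with the methyl on oxygen of compound 2.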